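The source may hold more compounds than are shown below. What is called first, only, known or untested is meant among the compounds shown, and "the series" means these compounds.

Working notes, cytotoxicity series.

Compound 1 `COc1ccc(CNc2ncnc3c2ncn3C2CCCCO2)cc1` is the reference. In an ADME assay on BJ cells (Homo sapiens) for cytotoxicity, read by MTT assay, with a stated time of 72 h (on this read-out lower numbers stand for stronger inhibition and higher numbers for weaker inhibition), compound 1 gives only a limit, > 100000 nM. Compound 2 `COc1ccc(CNc2ncnc3c2ncn3C2CCCCO2)c(OC)c1` carries the change (methoxy in place of hydrogen on an aromatic carbon). In this assay compound 2 also gives only a limit, > 25000 nM. The step that the two limits leave unreadable from compound 1 to compound 2 cannot be sized because the limit of > 100000 nM in this assay, at which 2 of the 3 values shown sit, and the limit of > 25000 nM in this assay, at which 1 of the 3 values shown sits, are both limits rather than numbers.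

Compound 3 `COc1cccc(CNc2ncnc3c2ncn3C2CCCO2)c1` differs from compound 1 in its core, and that difference is not broken down here. In this assay compound 3 gives only a limit, > 100000 nM.

Compound 4 `COc1cc(CNc2ncnc3c2ncn3C2CCCO2)cc(OC)c1` is not yet measured; it carries methoxy in place of hydrogen on an aromatic carbon. This is the same kind of change as that from compound 1 to compound 2, not the same: the entering methoxy stands meta to a large group here, where in compound 2 it stood ortho to a large group; in both it is meta to a methoxy group. The step expected in this assay is a step that the limit leaves unreadable from compound 3 to compound 4. Among the measured compounds shown here, that expectation rests on compound 1 and compound 3 both sitting at the limit of > 100000 nM in this assay, at which 2 of the 3 values shown sit, and compound 2 sitting at the limit of > 25000 nM in this assay, at which 1 of the 3 values shown sits, so no measured step suggests any movement. In this assay compound 4 is expected to give 120000 nM, most likely reported again as a limit.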

Compound 4, half-maximal inhibitory concentration: > 100000 nM
Compound 4: a limit, no number; the forecaster's own chance of this, stated with the estimate: 85%; the middle value does not contradict the limit.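

Compound 3 and compound 4 both give only limits, so no step between them can be read in this assay: the limit of > 100000 nM in this assay, at which 3 of the 4 values shown sit.

The compounds shown leave open whether methoxy in place of hydrogen on an aromatic carbon changes the read-out in this assay at all, as no compound here has yet given a number.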